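The source may hold more compounds than are shown below. What is called first, only, known or untested is meant among the compounds shown, and "the series" means these compounds.

Measured compounds in a functional assay on MKN-45 cells (Homo sapiens) for cytotoxicity, read by MTT assay, with a stated time of 48 h; a higher number here means a weaker inhibitor, a lower number a stronger inhibitor:
Compound 1 `C=CCSc1nnc(CCC)n1N1C(=O)c2ccccc2C1=O`: compound 1 gives > 200000 nM, a limit of the assay.
Compound 2 `CCCc1nnc(SCC(=O)c2ccc(C)cc2)n1N1C(=O)c2ccccc2C1=O`: compound 2 gives > 200000 nM, a limit of the assay.
Compound 3 `CCCc1nnc(SCc2ccccc2Cl)n1N1C(=O)c2ccccc2C1=O`: compound 3 gives > 200000 nM, a limit of the assay.

Compound 3 thus stands only at a limit, and the two other values shown are limits as well (the limit of > 200000 nM in this assay, at which 3 of the 3 values shown sit). The unmeasured compound 4 `CCCc1nnc(SCC(=O)c2ccccc2)n1N1C(=O)c2ccccc2C1=O` differs from compound 3 in one place: benzoyl in place of 2-chlorophenyl on a saturated chain carbon bound to a sulfur. Of the measured steps, a step that the two limits leave unreadable from compound 1 to compound 3 and a step that the two limits leave unreadable from compound 2 to compound 3 concern the same saturated chain carbon bound to a sulfur, and a step that the two limits leave unreadable from compound 1 to compound 2 brings in a (4-methylphenyl)carbonyl that is close to the benzoyl entering here; none of the three has a readable size, each ending at a limit. Compound 2, carrying (4-methylphenyl)carbonyl at that carbon, sits at the limit, and compound 4 is expected to sit there too. The expected step that the limit leaves unreadable from compound 3 to compound 4 is none beyond the scatter. In this assay compound 4 is therefore estimated at 300000 nM, with a range of 150000 nM to 1000000 nM, most likely reported again only as a limit.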

Compound 4, half-maximal inhibitory concentration: > 200000 nM
Compound 4: a limit, no number; the forecaster's own chance of this, stated with the estimate: 90%; the middle value does not contradict the limit.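

Compound 4 ends at a limit of the assay, as do compound 1, compound 2 and compound 3, so no step among them can be read in this assay: the limit of > 200000 nM in this assay, at which 4 of the 4 values shown sit.
The compounds shown leave open whether any group on the saturated chain carbon bound to a sulfur gives a readable value.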